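Expected cytotoxicity of compound 3 from compound 1

A few compounds are considered here, and "the series" means these few. Any claim that something is new, unique, unknown or untested is made for them only; others in the source may bear on it.

Among the compounds with values here, in an ADME assay on MDCK cells (Canis lupus familiaris) for cytotoxicity, read by MTT assay, with a stated time of 48 h (a lower number here means that less compound is tolerated, a higher number that more compound is tolerated), compound 1 (`COC(=O)[C@@H](NC(=O)CSc1nc(-c2ccccc2)cc(-c2ccc(C)cc2)c1C#N)C(C)C`) gives 210000 nM, the only actual number so far. Compound 2 (`CC[C@H](C)[C@H](NC(=O)CSc1nc(-c2ccccc2)cc(-c2ccc(C)cc2)c1C#N)C(=O)OC`) gives > 250000 nM, which is a limit of the assay and not a number. Within the data shown here, the one measured step, an at least 1.1-fold higher number from compound 1 to compound 2 (0.07 log units; that floor lies within the scatter), is methyl in place of hydrogen on a saturated chain carbon, and its floor lies within the scatter.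

Compound 3 (`Cc1ccc(-c2cc(-c3ccccc3)nc(SCC(=O)N[C@H](C(=O)N[C@@H](CC(=O)O)C(=O)O)C(C)C)c2C#N)cc1`) carries a different change: (1,2-dicarboxyethyl)amino in place of methoxy on a carbonyl carbon. Among the measured compounds shown here, no measured step covers this change, so the only guide is the small step to compound 2 at > 250000 nM. The expected step is a 1.1-fold higher number from compound 1 to compound 3 (0.06 log units; within the scatter), with nothing beyond the scatter expected in this assay. For compound 3 the estimated value is 240000 nM, with an expected range of 90000 nM to 450000 nM.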

Compound 3, half-maximal cytotoxic concentration: > 250000 nM
Compound 3: a limit, no number (the forecaster's own chance of this, stated with the estimate: 50%); middle value at least 1.0-fold (0.01 log units) away from the limit.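

In this assay, (1,2-dicarboxyethyl)amino in place of methoxy on a carbonyl carbon gives an at least 1.1-fold higher number from compound 1 to compound 3 (0.07 log units; that floor lies within the scatter). Compound 3 gives > 250000 nM, which is a limit of the assay and not a number. The earlier compounds covered only a methyl change on the saturated chain, whereas this result shows that the carbonyl carbon can carry a group of 9 heavy atoms instead of 2 with no lower number, though only the floor of the step can be read: the limit of > 250000 nM in this assay, at which 2 of the 3 values shown sit.

On these data alone, how far compound 3 lies from compound 1 remains open, as does which part of the (1,2-dicarboxyethyl)amino group bears on the result. A plain hydroxy group or a simple amine on the same carbonyl carbon would show whether smaller replacements for methoxy read the same way.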